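Trimethoxyphenyl for Naphthyl on a Coumarin-Triazole Dienone

The compounds below may be only part of what the source reports. "The series", "measured", "known", "first", "only" and "open" are said of these compounds alone.

Measured so far in a functional assay on COLO 205 cells (Homo sapiens) for inhibition, read by sulforhodamine B assay, with a stated time of 48 h, tested at 50 uM; a lower number here means less inhibition of growth, a higher number more inhibition of growth at the concentration tested:
compound 1 `COc1ccc(/C=C/C(=O)/C=C/c2ccc(OCc3cn(CCCCCOc4cc(=O)oc5ccccc45)nn3)c(OC)c2)cc1` gives 30%
compound 2 `COc1cc(/C=C/C(=O)/C=C/c2cccc3ccccc23)ccc1OCc1cn(CCCCOc2cc(=O)oc3ccccc23)nn1` gives 50%
compound 3 `COc1cccc(/C=C/C(=O)/C=C/c2ccc(OCc3cn(CCOc4cc(=O)oc5ccccc45)nn3)c(OC)c2)c1` gives 69%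

Compound 2 holds the second highest of the three numbers. Its nearest neighbour is compound 3, whose number lies beyond the scatter above it, and its furthest is compound 1, whose number lies beyond the scatter below it. The unmeasured compound 4 `COc1cc(/C=C/C(=O)/C=C/c2cc(OC)c(OC)c(OC)c2)ccc1OCc1cn(CCCCOc2cc(=O)oc3ccccc23)nn1` differs from compound 2 in one place: 3,4,5-trimethoxyphenyl in place of naphthalen-1-yl on a double-bonded chain carbon bound to a double-bonded chain carbon. Within the data shown here, no step between measured compounds isolates such a change, so the direction is open. She expects the step of a number 5 percentage points lower from compound 2 to compound 4 (within the scatter) to stay within the scatter, with the wide range reflecting how far compound 1 and compound 3 spread around compound 2. Compound 4 is therefore estimated at 45%, between 20% and 75%.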

Compound 4, percent growth inhibition at one concentration: 60%
For compound 4 the middle estimate is 15 percentage points below the measured one, and the stated range covers the measured number.
By their numbers in this assay, from the lowest: compound 1; then compounds 2, 4 and 3 (each within the scatter of the next, the first and the last beyond it).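

In this assay, among these compounds, 3,4,5-trimethoxyphenyl in place of naphthalen-1-yl on a double-bonded chain carbon bound to a double-bonded chain carbon gives a number 10 percentage points higher from compound 2 to compound 4 (within the scatter), the first step that isolates this position. A single aromatic ring with three hydrogen-bond acceptors thus reads within the scatter of the two-ring group it replaces. Nothing available explains this result.

As far as these compounds go, whether an amine or a carboxylic acid at this position would read the same remains open. Compound 1 and compound 3 differ from these compounds in more than one place, so the effect of a longer chain cannot be read.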